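A few compounds are considered here, and "the series" means these few. Any claim that something is new, unique, unknown or untested is made for them only; others in the source may bear on it.

Measured so far:
- compound 1, `Cc1cc(=O)c2c(O)cc(OCc3ccco3)c([C@H]3CCN(C)C[C@H]3O)c2o1`: 14%
- compound 2, `Cc1cc(=O)c2c(O)c(CN3CCCCC3)c(O)c([C@H]3CCN(C)C[C@H]3O)c2o1`: 14%
- compound 3, `Cc1oc2c([C@H]3CCN(C)C[C@H]3O)c(O)cc(O)c2c(=O)c1C(O)c1ccc([N+](=O)[O-])cc1`: 24%

All three were tested in a functional assay on PC-3 cells (Homo sapiens) for inhibition, read by MTT assay, with a stated time of 48 h, tested at 10 uM; on this read-out lower numbers stand for less inhibition of growth and higher numbers for more inhibition of growth at the one concentration tested. Compound 1 gives 14%, compound 2 gives 14% and compound 3 gives 24%. Compound 3 sits at the upper end of the three numbers, but the values of compound 1 and compound 2 both lie within the usual scatter of it, so the three compounds cannot be told apart on these data; none of them inhibits growth strongly at the one concentration tested.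

Compound 4, `Cc1oc2c([C@H]3CCN(C)C[C@H]3O)c(O)cc(O)c2c(=O)c1C(O)c1cc(F)cc(F)c1`, has not yet been measured. It differs from compound 3 in one place: 3,5-difluorophenyl in place of 4-nitrophenyl on a saturated chain carbon bound to an aromatic carbon and an oxygen on a saturated carbon. Within the data shown here, no pair of measured compounds shows what such a change does, so there is no step to lean on. The expectation is therefore that the step of a number 2 percentage points lower from compound 3 to compound 4 (within the scatter) in this assay will stay within the scatter, with no direction favoured. Compound 4 is estimated at 22%, in a range from 8% to 38%.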

Compound 4, percent growth inhibition at one concentration: 0%
Compound 4: middle estimate off by 22 percentage points, on the high side, outside the stated range (below it).
By their numbers in this assay, from the lowest: compound 4; then compounds 1, 2 and 3 (each within the scatter of the next).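

Among these compounds, this is the first sign that the group on a saturated chain carbon bound to an aromatic carbon and an oxygen on a saturated carbon matters in this assay: 3,5-difluorophenyl in place of 4-nitrophenyl gives a number 24 percentage points lower from compound 3 to compound 4 (beyond the scatter). Among the compounds shown here, the earlier compounds all lay within the scatter of one another, so this is the first difference in the set that can be read as real. Nothing measured here accounts for the difference.

The change removes the nitro group and brings in two fluorines at once, so the compounds shown cannot separate the part played by each. Also open, from the compounds shown here alone, is how plain phenyl, 4-fluorophenyl or 4-aminophenyl would behave at this place.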